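Compound 2 to compound 4: changing the aryl group

The source may hold more compounds than are shown below. What is called first, only, known or untested is meant among the compounds shown, and "the series" means these compounds.

Measured in a physicochemical assay for solubility, read by HPLC, using the shake flask method, in phosphate buffer, with a stated time of 20 h, at pH 6.5; on this read-out lower numbers stand for lower solubility and higher numbers for higher solubility:
- compound 1 `NC1CCN(c2nccc3[nH]c(-c4ccc(F)c(F)c4)nc23)CC1`: 200000 nM
- compound 2 `CN1CCN(CC2CCN(c3nccc4[nH]c(-c5ccc(F)c(F)c5)nc34)CC2)CC1`: 195000 nM
- compound 3 `CN1CCN(C(=O)C2CCN(c3nccc4[nH]c(-c5ccc(F)c(F)c5)nc34)CC2)CC1`: 200000 nM

The value of compound 2, 195000 nM, cannot be separated from the other two, as all three compounds lie within the scatter of one another. Compound 4 `CN1CCN(CC2CCN(c3nccc4[nH]c(-c5cccc(OC(F)(F)F)c5)nc34)CC2)CC1` has 3-(trifluoromethoxy)phenyl in place of 3,4-difluorophenyl on an aromatic carbon.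

Three measured steps exist, all on a saturated ring carbon: a 1.0-fold lower number from compound 1 to compound 2 (0.01 log units; within the scatter), no change at the digits printed from compound 1 to compound 3 (within the scatter) and a 1.0-fold higher number from compound 2 to compound 3 (0.01 log units; within the scatter). Each stays within the scatter, but none touches the aromatic carbon changed here, so they bear on this step only indirectly. For the measured compounds named here, no measured step tests this aryl exchange. The expected outcome in this assay is no step beyond the scatter, with the range left wider on the low side.

The expected step is a 1.1-fold lower number from compound 2 to compound 4 (0.06 log units; within the scatter).

For compound 4 the estimated value is 170000 nM, with an expected range of 70000 nM to 230000 nM.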

Compound 4, solubility: 200000 nM
Estimate against measurement, compound 4: 1.2-fold (0.07 log units) below; measured number inside the range.
By their numbers in this assay, from the lowest: compounds 2, 1, 3 and 4 (each within the scatter of the next).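

The only step shown on the aromatic carbon of the five-membered ring, 3-(trifluoromethoxy)phenyl in place of 3,4-difluorophenyl, gives a 1.0-fold higher number from compound 2 to compound 4 (0.01 log units; within the scatter) in this assay on the side chain of compound 2. The earlier steps shown here covered only the saturated ring carbon, so both places now have a measured change within the scatter, here with 11 heavy atoms entering against 8 and a hydrogen-bond acceptor gained. Nothing on hand gives a reason for this outcome.

This aryl exchange is shown only with the side chain of compound 2, so its outcome with the amino group of compound 1 or the carbonyl-linked side chain of compound 3 stays open. Also open, going by these compounds, is whether a phenyl bearing a carboxylic acid or an amine at this place would give a step beyond the scatter.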